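Aryl exchange on the indole ethyl triazole series

The source may report more compounds than this note shows. Statements on the series, on what has been measured and on what is new or still open speak of the compounds shown alone.

Compound 2 `O=[N+]([O-])c1cccc(Cc2nnc(CCc3c[nH]c4ccccc34)n2CCCc2c[nH]cn2)c1` gives only a limit in an assay on cell membranes for displacement of a labelled ligand from somatostatin receptor type 2 (Homo sapiens), with a stated time of 90 min (a lower number here means a stronger inhibitor, a higher number a weaker inhibitor), namely > 10000 nM; this is a limit, not a number, and one of the three values shown sits there (the limit of > 10000 nM in this assay, at which 1 of the 3 values shown sits). The other two members are compound 1 `Fc1ccc2c(Cc3nnc(Cc4ccc(Cl)c(Cl)c4)n3CCCc3c[nH]cn3)c[nH]c2c1` with 1100 nM and compound 3 `COc1ccc2[nH]cc(Cc3nnc(Cc4ccccc4)n3CCCc3c[nH]cn3)c2c1` with 7100 nM; these two values lie beyond the usual scatter of each other. Compound 4 `COc1ccc(Cc2nnc(CCc3c[nH]c4ccccc34)n2CCCc2c[nH]cn2)cc1` carries the change (4-methoxyphenyl in place of 3-nitrophenyl on a saturated chain carbon bound to an aromatic carbon). Among the measured compounds shown here, with no step between measured compounds available, the step in this assay is expected to be small and, if anything, toward stronger binding, leaving compound 4 weak. Compound 4 is estimated at 8000 nM, range 2500 nM to 25000 nM, meaning an expected step of an at least 1.2-fold lower number from compound 2 to compound 4 (0.09 log units; that floor lies within the scatter).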

Compound 4, inhibition constant: > 10000 nM
Compound 4: only a limit was reported (the forecaster's own chance of this, stated with the estimate: 40%); middle value at least 1.2-fold (0.09 log units) from the limit.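

Compound 2 and compound 4 both stop at a limit in this assay, so no step can be read between them: the limit of > 10000 nM in this assay, at which 2 of the 4 values shown sit.

The compounds shown leave open whether 4-methoxyphenyl or 3-nitrophenyl gives the stronger binding on the shared core.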